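A Triazole Aryl Swap at the Edge of Activity

A few compounds are considered here, and "the series" means these few. Any claim that something is new, unique, unknown or untested is made for them only; others in the source may bear on it.

compound 1 `N#CC1=C(N)Oc2c(c3nc4ccccc4nc3c3ccccc23)C12C(=O)N(Cc1cnnn1-c1ccccc1Cl)c1ccccc12` — 42600 nM
compound 2 `COc1ccc(-n2nncc2CN2C(=O)C3(C(C#N)=C(N)Oc4c3c3nc5ccccc5nc3c3ccccc43)c3ccccc32)cc1` — > 50000 nM

Among the compounds with values here, in a functional assay on A549 cells (Homo sapiens) for antiproliferative activity, read by MTT assay, with a stated time of 48 h (on this read-out higher numbers stand for weaker inhibition and lower numbers for stronger inhibition), compound 1 gives 42600 nM, the only number among the two values shown. Compound 2 gives only a limit of the assay, > 50000 nM. That is the limit of > 50000 nM in this assay, at which 1 of the 2 values shown sits. Within the data shown here, the one measured change at this position is an at least 1.1-fold higher number from compound 1 to compound 2 (0.06 log units; that floor lies within the scatter), whose floor lies within the scatter. Compound 3 `N#CC1=C(N)Oc2c(c3nc4ccccc4nc3c3ccccc23)C12C(=O)N(Cc1cnnn1-c1ccc(N)cc1)c1ccccc12` differs from compound 1 by 4-aminophenyl in place of 2-chlorophenyl on an aromatic nitrogen. Compound 1 sits at 42600 nM. Among the measured compounds shown here, with the only neighbouring step, an at least 1.1-fold higher number from compound 1 to compound 2 (0.06 log units; that floor lies within the scatter), ending at a limit of the assay, no step beyond the scatter is expected. The estimated step is a 1.1-fold higher number from compound 1 to compound 3 (0.02 log units; within the scatter). Compound 3 is expected at 45000 nM, within 20000 nM to 100000 nM.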

Compound 3, half-maximal inhibitory concentration: > 50000 nM
Compound 3: no number, only a limit; the forecaster's own chance of this, stated with the estimate: 45%; at least 1.1-fold (0.04 log units) between middle value and limit.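

The 4-aminophenyl group, like 4-methoxyphenyl, ends at a limit of the assay, with an at least 1.1-fold higher number from compound 1 to compound 3 (0.06 log units; that floor lies within the scatter) in this assay. Amino in place of methoxy gives a step that cannot be read, as both values are limits. Only the 2-chlorophenyl compound thus keeps a number, and the series now gathers at the top of the range: the limit of > 50000 nM in this assay, at which 2 of the 3 values shown sit.

Going by these compounds, how a plain phenyl or a fluorophenyl on this nitrogen would read stays open. So does whether any group here gives a number clearly lower than that of compound 1.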